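Compound 3 to compound 4: a larger amide substituent

The source may hold more compounds than are shown below. What is called first, only, known or untested is meant among the compounds shown, and "the series" means these compounds.

Measured so far:
compound 1 `CCOC(=O)C1(C(=O)NCc2ccc(C)cc2)CC1c1cc(OC)c(OC)c(OC)c1`: 33200 nM; 25600 nM (2 entries)
compound 2 `CCOC(=O)[C@]1(C(=O)NCc2ccc(C)cc2)C[C@H]1c1cc(OC)c(OC)c(OC)c1`: 28500 nM
compound 3 `CCOC(=O)[C@@]1(C(=O)Nc2ccccc2)C[C@H]1c1cc(OC)c(OC)c(OC)c1`: > 100000 nM

In a functional assay on HeLa cells (Homo sapiens) for cytotoxicity, read by MTT assay, with a stated time of 48 h (on this read-out lower numbers stand for stronger inhibition and higher numbers for weaker inhibition), compound 1 gives 33200 nM; 25600 nM (2 entries) across repeated runs, as the several entries of compound 1 in this assay, 33200 nM; 25600 nM (2 entries) records. Compound 2 gives 28500 nM. Among the measured compounds shown here, compound 3 reaches only the limit of > 100000 nM, so no number is known for it; it is the one value sitting at that limit, as the limit of > 100000 nM in this assay, at which 1 of the 3 values shown sits, notes, and therefore stands at the weak end of what has been measured.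

Compound 4 `CCOC(=O)[C@@]1(C(=O)NCc2ccc(C)cc2)C[C@H]1c1cc(OC)c(OC)c(OC)c1` differs from compound 3 in one place: 4-methylbenzyl in place of phenyl on an amide-type nitrogen. For the measured compounds named here, no pair of measured compounds isolates this change, so its size is uncertain. Still, the entering group is present in compound 1 and compound 2, which both give numbers rather than limits, so a move toward stronger inhibition is expected. Compound 4 is therefore expected near 40000 nM, between 15000 nM and 150000 nM. That corresponds to an expected step of an at least 2.5-fold lower number from compound 3 to compound 4 (0.39 log units; beyond the scatter).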

Compound 4, half-maximal inhibitory concentration: 19700 nM
Estimate against measurement, compound 4: 2.0-fold (0.31 log units) above, and the stated range covers the measured number.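

In this assay, 4-methylbenzyl in place of phenyl on the amide nitrogen gives an at least 5.0-fold lower number from compound 3 to compound 4 (0.70 log units; beyond the scatter), the first step measured at this position. Compound 3 stands at a limit, so only a lowest possible size of that step is known. Drawn S rather than R, the stereocentre at a saturated ring carbon makes no difference beyond the scatter: a 1.4-fold lower number from compound 2 to compound 4 (0.16 log units; within the scatter). Still open, going by these compounds, is whether the step comes from the methyl group or from the extra carbon link to the ring. A plain benzyl group on that nitrogen would help to separate the two.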